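The source may report more compounds than this note shows. Statements on the series, on what has been measured and on what is new or still open speak of the compounds shown alone.

Measured in a functional assay on MGC-803 cells (Homo sapiens) for inhibition, read by MTT assay, with a stated time of 48 h; on this read-out lower numbers stand for stronger inhibition and higher numbers for weaker inhibition:
Compound 1 `COC(=O)c1cc(CNc2cc(OC)c(OC)c(OC)c2)ccc1OC`: 49600 nM
Compound 2 `COc1cc(NCc2ccc(Br)cc2)cc(OC)c1OC`: > 80000 nM (a limit of the assay)

Compound 2 stands at the limit > 80000 nM and has no number on this read-out. Compound 3 `COc1ccc(CNc2cc(OC)c(OC)c(OC)c2)cc1` keeps the rest of compound 2 and changes a single group (methoxy in place of bromo on an aromatic carbon), with methoxy in place of bromo on an aromatic carbon, para to a large group. Going by the values given here, no measured step between two compounds shows what such a swap does in this assay on its own. Among the compounds with values here, the only firm number is that of compound 1 at 49600 nM in this series, so the expectation leans on it alone. A moderate step towards stronger inhibition is expected, and the estimated size is an at least 1.7-fold lower number from compound 2 to compound 3 (0.24 log units; that floor lies within the scatter) on this reasoning. That step may turn out small, and compound 3 could also return only a limit. For compound 3 the estimated half-maximal inhibitory concentration is 45000 nM with an expected range from 12000 nM to 120000 nM in repeated measurements.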

Compound 3, half-maximal inhibitory concentration: 11400 nM
Compound 3: the middle estimate sits 3.9-fold (0.60 log units) above what was measured, and the stated range ends above it.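

In this assay, methoxy in place of bromo on an aromatic carbon, para to a large group, gives an at least 7.0-fold lower number from compound 2 to compound 3 (0.84 log units; beyond the scatter), the first sign in this series that the group at this position matters for inhibition of these cells. From the compounds shown here alone, compound 2 gives only a limit and not a number, so this step is a floor and its true size stays unknown: the limit of > 80000 nM in this assay, at which 1 of the 3 values shown sits. The second step gives a firm size beyond the scatter, as hydrogen in place of methoxycarbonyl on an aromatic carbon gives a 4.4-fold lower number from compound 1 to compound 3 (0.64 log units; beyond the scatter), which shows that compound 3 keeps its stronger inhibition without the methoxycarbonyl group.

The compounds shown leave open how a hydroxyl, a fluoro or an ethoxy group at the position para to the large group would compare with methoxy, and so whether methoxy itself matters or a wider set of groups would serve as well. They also leave open whether a carboxylic acid or an amide in place of the methoxycarbonyl group of compound 1 would give the same weaker inhibition as that ester.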